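Aminophenyl to dimethoxyphenyl on the carbonyl of compound 1

The source may hold more compounds than are shown below. What is called first, only, known or untested is meant among the compounds shown, and "the series" means these compounds.

Measured compounds:
compound 1 `COc1cc(-c2cc(/C=C/C(=O)c3ccc(N)cc3)[nH]n2)cc(OC)c1OC` 10500 nM
compound 2 `COc1ccc(-c2cc(/C=C/C(=O)c3ccc(OC)c(OC)c3)[nH]n2)cc1` 3650 nM
compound 3 `COc1ccc(-c2cc(/C=C/C(=O)c3cc(OC)c(OC)c(OC)c3)[nH]n2)cc1OC` 8610 nM

In a functional assay on IGROV-1 cells (Homo sapiens) for inhibition, read by sulforhodamine B assay, with a stated time of 48 h (on this read-out higher numbers stand for weaker inhibition of growth and lower numbers for stronger inhibition of growth), compound 1 gives the highest of the three numbers. Compound 3 stands nearest to it, within the scatter, so no order between compound 1 and compound 3 can be read from these two values. Compound 2 stands furthest from compound 1 and that gap lies beyond the scatter, so compound 2 inhibits growth more strongly than compound 1.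

The next compound, compound 4 `COc1ccc(C(=O)/C=C/c2cc(-c3cc(OC)c(OC)c(OC)c3)n[nH]2)cc1OC`, has not yet been measured in this assay. Relative to compound 1 the change is 3,4-dimethoxyphenyl in place of 4-aminophenyl on a carbonyl carbon. Compound 4 thus carries the same group on the carbonyl carbon that compound 2 carries, while compound 2 differs from compound 4 elsewhere. For the measured compounds named here, no single-change step between measured compounds is available, so the direction rests on the values of compound 1 and compound 2 alone. Compound 4 is expected to give a lower number than compound 1, a step of a 2.1-fold lower number from compound 1 to compound 4 (0.32 log units; beyond the scatter) of modest size and possibly not beyond the scatter. The estimate for compound 4 is 5000 nM, within 2000 nM to 12000 nM.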

Compound 4, concentration for total growth inhibition: 3410 nM
Estimate against measurement, compound 4: 1.5-fold (0.17 log units) above; the range from low to high includes it.
By their numbers in this assay, from the lowest: compounds 4 and 2 (each within the scatter of the next); then compounds 3 and 1 (each within the scatter of the next).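

In this assay the change of 4-aminophenyl to 3,4-dimethoxyphenyl on a carbonyl carbon gives a 3.1-fold lower number from compound 1 to compound 4 (0.49 log units; beyond the scatter), so inhibition of growth strengthens modestly while the rest of compound 1 stays the same. For the compounds shown here, earlier, the group at this position could be followed only through compounds that also differed elsewhere, whereas this step isolates it for the first time. No measurement here explains the step.

On these data alone, it remains open whether the two methoxy groups are both needed, since a single-methoxy 4-methoxyphenyl group or an unsubstituted phenyl group at this position would be required to separate them. Also open, as far as these compounds go, is how other groups on the carbonyl carbon, such as 4-hydroxyphenyl or 4-dimethylaminophenyl, compare with 4-aminophenyl on the core of compound 1.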